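Methoxy to Hydroxy on the Aromatic Ring of Compound 1

The source may hold more compounds than are shown below. What is called first, only, known or untested is meant among the compounds shown, and "the series" means these compounds.

Compound 1 `COc1ccc(C(=O)O[C@H]2CC(C)=CC[C@@]3(C)CC[C@@](O)(C(C)C)[C@H]23)cc1` and compound 2 `COc1ccc(C(=O)O[C@@H]2C=C(C)CC[C@]3(O)[C@H](C(C)C)CC(=O)[C@]23C)cc1` both carry a 4-methoxyphenyl group and were both tested in a functional assay on SEM cells (Homo sapiens) for cytotoxicity, read by MTT assay, with a stated time of 72 h; a higher number here means a weaker inhibitor, a lower number a stronger inhibitor. In this assay compound 1 gives 18200 nM, and compound 2 gives 23900 nM. Compound 1 stands at the lower of these two numbers, yet its gap to compound 2 lies within the scatter, so the two compounds cannot be told apart on these data. Compound 3 `CC1=CC[C@@]2(C)CC[C@@](O)(C(C)C)[C@@H]2[C@@H](OC(=O)c2ccc(O)cc2)C1` has not yet been measured; it differs from compound 1 by hydrogen in place of methyl on an oxygen on an aromatic ring. Within the data shown here, no measured pair in this small set mirrors that change, so any expectation has to rest on compound 1 and its value alone. With the methyl leaving the oxygen on the aromatic ring and hydrogen entering, and nothing in the set showing that such a change moves the read-out, the step from compound 1 to compound 3 is expected to be small, most likely within the scatter in either direction, as a 1.2-fold lower number from compound 1 to compound 3 (0.08 log units; within the scatter). Compound 3 is therefore estimated at 15000 nM in this assay, with a range from 6000 nM to 40000 nM.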

Compound 3, half-maximal inhibitory concentration: > 100000 nM
Compound 3 was reported as a limit; the forecaster's own chance of this, stated with the estimate: 10%; at least 6.6-fold (0.82 log units) between middle value and limit.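

Among these compounds, the methyl on the oxygen on an aromatic ring turns out not to be a silent part of compound 1, something the earlier compounds could not show, since both carry the same 4-methoxyphenyl group: with hydrogen in its place, the read-out shifts to weaker inhibition, as an at least 5.4-fold higher number from compound 1 to compound 3 (0.73 log units; beyond the scatter). In this assay, the entry for compound 3 is a limit of the assay and not a number: the limit of > 100000 nM in this assay, at which 1 of the 3 values shown sits. The step therefore gives the direction of the change and a minimum size, and it shows that, on the core of compound 1, going from 4-methoxyphenyl to 4-hydroxyphenyl is enough on its own to carry the read-out beyond the scatter, though this rests on one pair only.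

The compounds shown leave open how far the true value of compound 3 lies beyond its limit, and whether the same change on the core of compound 2 would move the number in the same way. They also leave open whether a longer chain on that oxygen, such as ethoxy, or an amine or a fluorine atom in place of the methoxy group, would stay close to compound 1 or follow compound 3.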